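Notes on the methoxy analogue of compound 2

The compounds below may be only part of what the source reports. "The series", "measured", "known", "first", "only" and "open" are said of these compounds alone.

Three compounds on the shared core have been run in a functional assay, read by spectrophotometry, with a stated time of 15 min, tested at 20 ug/mL; on this read-out higher numbers stand for a stronger effect at the one concentration tested and lower numbers for a weaker effect. Compound 1 `Fc1ccc(-c2csc(N/N=C/c3ccc(Cl)cc3Cl)n2)cc1` gives 88.4%. Compound 2 `Cc1ccc(-c2csc(N/N=C/c3ccc(Cl)cc3Cl)n2)cc1` gives 76.2%, the second highest of the three numbers, with compound 1 its nearest neighbour above and compound 3 `COC(=O)c1cc(-c2csc(N/N=C/c3ccc(Cl)cc3Cl)n2)ccc1OCc1ccccc1`, at 58.9%, the furthest below. For the measured compounds named here, the single step that differs in one place, a number 12.2 percentage points lower from compound 1 to compound 2 (beyond the scatter), came from methyl in place of fluoro on an aromatic carbon.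

Compound 4 `COc1ccc(-c2csc(N/N=C/c3ccc(Cl)cc3Cl)n2)cc1` is not yet measured. Against compound 2 the change is methoxy in place of methyl on an aromatic carbon, on an aromatic carbon of a six-membered aromatic ring of carbon only, para to a large group; cut one bond further out it reads 4-methylphenyl to 4-methoxyphenyl. Going by the values given here, no measured step exchanges methyl for methoxy, so none bears on it directly; the step from compound 1 to compound 2 shows only that a change at this carbon moved this assay by a modest amount. Among the compounds with values here, compound 3, the most heavily substituted of the three, sits lowest, but no single-place step connects it to compound 2. The expectation for compound 4 is therefore a step of a number 4.2 percentage points lower from compound 2 to compound 4 (within the scatter), not clearly beyond the scatter in either direction. Compound 4 is estimated at 72%, within 56% to 86%.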

Compound 4, a percentage reported as inhibition, at one concentration (the size of the read-out at that concentration, not a potency): 78.1%
The estimate for compound 4 lay 6.1 percentage points below the measured number; low and high end bracket the measured number.
By their numbers in this assay, from the lowest: compound 3; then compounds 2 and 4 (each within the scatter of the next); then compound 1.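

In this assay, methoxy in place of methyl on this aromatic carbon, para to a large group, gives a number 1.9 percentage points higher from compound 2 to compound 4 (within the scatter), so this assay does not separate 4-methylphenyl from 4-methoxyphenyl, even though the entering methoxy brings an oxygen and a hydrogen-bond acceptor that methyl lacks. Fluoro is the group that stands apart at this position: a number 10.3 percentage points lower from compound 1 to compound 4 (beyond the scatter), which agrees in direction with a number 12.2 percentage points lower from compound 1 to compound 2 (beyond the scatter), so both exchanges away from fluoro lie beyond the scatter, while the exchange between methyl and methoxy does not. Nothing on hand speaks to what lies behind this separation of fluoro from the other two groups.

Still open, as far as these compounds go, is whether an amine, a carboxylic acid or a longer chain at this carbon would read with methyl and methoxy, with fluoro, or apart from both, and whether chloro or trifluoromethyl would fall on the side of fluoro. Since the read-out comes from one concentration, these compounds also leave open whether the stronger and weaker effects seen at that concentration, and the same grouping of fluoro, methyl and methoxy, would hold across a concentration range.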